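The source may report more compounds than this note shows. Statements on the series, on what has been measured and on what is new or still open speak of the compounds shown alone.

In a physicochemical assay for lipophilicity, read by HPLC (a lower number here means a more polar compound, a higher number a more lipophilic compound), compound 1 `COC(=O)C1(c2ccc(NC(=O)Nc3cccnc3Oc3ccccc3C(C)(C)C)cc2)CC1` gives 5.1 as its reading, compound 2 `CC(C)(C)c1ccccc1Oc1ncccc1NC(=O)Nc1ccc(N2CCCCC2)cc1` gives 5.5 and compound 3 `CC(C)CCN1CCC(COc2ccc(NC(=O)Nc3cccnc3Oc3ccccc3C(C)(C)C)c(F)c2)CC1` gives 5.5 on the same scale. Compound 2 thus stands level with compound 3 at the top of these three numbers. Compound 4 `CC(C)CN1CCC(COc2ccc(NC(=O)Nc3cccnc3Oc3ccccc3C(C)(C)C)cc2)CC1` carries (1-isobutylpiperidin-4-yl)methoxy in place of piperidin-1-yl on an aromatic carbon. Going by the values given here, the only measured step that bears on this change is the one that brought piperidin-1-yl in (a number 0.40 log units higher from compound 1 to compound 2 (beyond the scatter)), a modest rise beyond the scatter. It does not cover the exchange itself, so it serves only as a rough guide to how far a change at this place can move this assay. With compound 3 at 5.5 as the other high reading, no step beyond the scatter is expected, and a slight fall is as far as the estimate goes. The estimated step is small (a number 0.10 log units lower from compound 2 to compound 4 (within the scatter)) and stays within the scatter. For compound 4 the estimated value is 5.4 in this assay, with an expected range from 5 to 5.8 for that reading.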

Compound 4, partition coefficient: 4.5
For compound 4 the middle estimate is 0.90 log units above the measured one; the measured number lies below the stated range.
By their numbers in this assay, from the lowest: compound 4; then compound 1; then compounds 2 and 3 (each within the scatter of the next).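

In this assay the place para to a large group can also lower the reading, not only raise it: (1-isobutylpiperidin-4-yl)methoxy in place of piperidin-1-yl gives a number 1.00 log units lower from compound 2 to compound 4 (beyond the scatter) and this step lies beyond the scatter. The same group in place of 1-(methoxycarbonyl)cyclopropyl gives a number 0.60 log units lower from compound 1 to compound 4 (beyond the scatter) and so also lies beyond the scatter, which shows that the larger entering group, with 12 heavy atoms, does not raise the number at this place. Nothing measured here explains the fall.

The exchange adds an oxygen, a linking carbon and an isobutyl group together, so the compounds shown do not say which part carries the step. As far as these compounds go, how a plain methoxy, an unsubstituted piperidin-4-ylmethoxy or a carboxylic acid would read at this place remains open.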